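The source may report more compounds than this note shows. Statements on the series, on what has been measured and on what is new or still open speak of the compounds shown alone.

Measured in an ADME assay on Raji cells (Homo sapiens) for cytotoxicity, read by CellTiter-Glo, with a stated time of 72 h; on this read-out lower numbers stand for an effect already at smaller amounts and higher numbers for an effect only at larger amounts of compound:

- compound 1 `C=C1/C=C/C(C)(C)CC2=C(C)C(=O)[C@]3(C[C@@H](C)C=C3/C=C\1C)O2`: 26000 nM
- compound 2 `C/C1=C/C2=C[C@H](C)C[C@@]23O[C@]2(CC(C)(C)C[C@@H]2[C@@]1(O)C#N)[C@@H](C)C3=O`: 26000 nM
- compound 3 `C/C1=C/C2=C[C@H](C)C[C@@]23O[C@]2(CC(C)(C)[C@@H](O)[C@@H]2C1=O)[C@@H](C)C3=O`: 26000 nM

The three measured compounds share a single reading in this assay. Compound 3, at 26000 nM, stands level with both compound 1 and compound 2, and nothing separates them at the digits reported.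

The next compound to be tested is compound 4 `CO[C@H]1[C@@H]2C(=O)/C(C)=C\C3=C[C@H](C)C[C@@]34O[C@]2(CC1(C)C)[C@@H](C)C4=O`. It comes from compound 3 by one change, methyl in place of hydrogen on an oxygen on a saturated carbon, which reads as hydroxy to methoxy: methyl in place of hydrogen on an oxygen on a saturated carbon.

Within the data shown here, no pair of measured compounds differs in one place only, so the data show no direct precedent for the size of such a change. Among the measured compounds shown here, the only guide is the common reading, with compound 1 at 26000 nM and compound 2 at 26000 nM, matching compound 3. On that basis, no shift beyond the usual scatter is expected in this assay, and no direction is favoured. The estimated step is no change at the digits printed from compound 3 to compound 4 (within the scatter).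

For compound 4 the expected value is 26000 nM, with an estimated range from 12000 nM to 50000 nM.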

Compound 4, half-maximal effective concentration: 26000 nM
For compound 4 middle estimate and measured number coincide at the digits printed; the measured number falls inside the stated range.
By their numbers in this assay, from the lowest: compounds 1, 2, 3 and 4 (each within the scatter of the next).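

In this assay, hydroxy to methoxy, methyl in place of hydrogen on an oxygen on a saturated carbon, gives no change at the digits printed from compound 3 to compound 4 (within the scatter). Compound 3 and compound 4 are the only pair shown that differ in one place, so this position now has a direct reading where the earlier compounds offered only a common value without any single-change comparison. Among these compounds, on this read-out, exchanging that hydrogen for methyl leaves the number unmoved, and the one step is the whole of what can be said about the position; nothing measured here offers an explanation for the result.

The compounds shown leave open whether a longer chain such as n-butyl, or an acetyl group, on this same oxygen would also leave the reading in this assay in place, or whether an amine standing where the oxygen stands would shift it. They also leave open whether the same exchange of hydrogen for methyl would read alike at any other oxygen of the shared core, as this single pair speaks for one place only.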